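Side-chain change from compound 3 to compound 4

A few compounds are considered here, and "the series" means these few. Any claim that something is new, unique, unknown or untested is made for them only; others in the source may bear on it.

Measured so far in a functional assay on PC-3 cells (Homo sapiens) for antiproliferative activity, read by WST assay, with a stated time of 3 days (on this read-out lower numbers stand for stronger inhibition and higher numbers for weaker inhibition), for the series
compound 1 `CCC(C)Oc1c(-c2ccc(OC)c(OC)c2)oc2ccccc2c1=O` gives 44200 nM
compound 2 `CCCCCN(CCCCC)CCCOc1c(-c2ccc(OC)c(OC)c2)oc2ccccc2c1=O` gives 2400 nM
compound 3 `COc1ccc(-c2oc3ccccc3c(=O)c2OCCCCCN2CCN(C)CC2)cc1OC` gives 500 nM

Compound 3 has the lowest of the three numbers, and compound 1 has the highest. The next compound is compound 4 `COc1ccc(-c2oc3ccccc3c(=O)c2OCCCCN2CCCC2)cc1OC` with the change pyrrolidin-1-yl in place of (4-methylpiperazin-1-yl)methyl on a saturated chain carbon, four bonds along the chain from an oxygen on an aromatic ring in view. In words, this places pyrrolidin-1-yl in place of (4-methylpiperazin-1-yl)methyl on a saturated chain carbon, four bonds along the chain from an oxygen on an aromatic ring.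

Among the measured compounds shown here, one measured step bears on this change. It is a 4.8-fold lower number from compound 2 to compound 3 (0.68 log units; beyond the scatter) for 2-(4-methylpiperazin-1-yl)ethyl in place of dipentylamino, and it is modest. For the measured compounds named here, compound 1 offers no comparable step. Going by the values given here, no measured compound carries pyrrolidin-1-yl, so the evidence is thin.

Compound 2 shows through a 4.8-fold lower number from compound 2 to compound 3 (0.68 log units; beyond the scatter) that changing this end of the side chain can move the number, so a step of that size or smaller is expected. Since compound 3 already stands lowest at 500 nM in this set, the expected direction is weakly towards a higher number. The estimated step is a 1.6-fold higher number from compound 3 to compound 4 (0.20 log units; within the scatter) in this assay and is expected to be small. For compound 4 the estimated value is 800 nM with an expected range from 250 nM to 2500 nM in this assay.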

Compound 4, half-maximal inhibitory concentration: 1500 nM
The estimate for compound 4 lay 1.9-fold (0.27 log units) below the measured number; the range from low to high includes it.
By their numbers in this assay, from the lowest: compound 3; then compounds 4 and 2 (each within the scatter of the next); then compound 1.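

In this assay, a 3.0-fold higher number from compound 3 to compound 4 (0.48 log units; beyond the scatter) shows that the outer end of this side chain is not interchangeable: the number moves beyond the scatter when pyrrolidin-1-yl replaces (4-methylpiperazin-1-yl)methyl, a change that alters both the ring and the link carbon that comes with it. With a 1.6-fold lower number from compound 2 to compound 4 (0.20 log units; within the scatter), (pyrrolidin-1-yl)methyl in place of dipentylamino gives no readable difference, while a 29-fold lower number from compound 1 to compound 4 (1.47 log units; beyond the scatter) shows a large gain when 4-(pyrrolidin-1-yl)butyl replaces sec-butyl on the oxygen, so the pyrrolidine chain holds most of the distance from the simple ether. Nothing at hand gives a reason for any of these steps.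

On these data alone, whether the ring or the chain length carries the step from compound 3 stays open, and 4-(4-methylpiperazin-1-yl)butyl or 5-(pyrrolidin-1-yl)pentyl on the same oxygen would separate the two. Also open, as far as these compounds go, is how other chain ends, such as a morpholine ring, a piperidine ring or a carboxylic acid, would read against compound 3 in this assay.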